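Chloro in place of methoxy on a shared core

A few compounds are considered here, and "the series" means these few. Any claim that something is new, unique, unknown or untested is made for them only; others in the source may bear on it.

In an ADME assay on microsomes from liver (Rattus norvegicus, strain Sprague-Dawley) for pharmacokinetics, read by LC-MS, using NADPH, with a stated time of 45 min, tested at 1 uM (on this read-out lower numbers stand for slow clearance and higher numbers for fast clearance), compound 1 `Nc1nccc(COc2ccc3nc(N[C@@H]4CCCC[C@H]4O)sc3c2)c1Cl` gives 68 mL/min/kg and compound 2 `COc1cc(OCc2ccnc(N)c2Cl)cc2sc(N[C@@H]3CCCC[C@H]3O)nc12` gives 99 mL/min/kg, two numbers that lie within the usual scatter of each other. Compound 3 `Nc1nccc(COc2cc(Cl)c3nc(N[C@@H]4CCCC[C@H]4O)sc3c2)c1Cl` has not been measured yet. It differs from compound 2 by a single swap, chloro in place of methoxy on an aromatic carbon. For the measured compounds named here, only one measured step concerns that carbon, methoxy in place of hydrogen, and it is a 1.5-fold higher number from compound 1 to compound 2 (0.16 log units; within the scatter). Going by the values given here, that step stayed within the scatter, and no measured compound yet carries chloro on that carbon, so no change beyond the scatter is expected in this assay. The estimated step is a 1.2-fold lower number from compound 2 to compound 3 (0.09 log units; within the scatter). For compound 3 the expected clearance is 80 mL/min/kg, with an estimated range from 42 mL/min/kg to 140 mL/min/kg.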

Compound 3, clearance: 78 mL/min/kg
Estimate against measurement, compound 3: 1.0-fold (0.01 log units) above; the measured number falls inside the stated range.
By their numbers in this assay, from the lowest: compounds 1, 3 and 2 (each within the scatter of the next).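

In this assay, this aromatic carbon has now carried hydrogen, methoxy and chloro, and the third group adds a second single swap that stays within the scatter. Chloro in place of methoxy gives a 1.3-fold lower number from compound 2 to compound 3 (0.10 log units; within the scatter), and chloro in place of hydrogen gives a 1.1-fold higher number from compound 1 to compound 3 (0.06 log units; within the scatter), so none of the three groups sets its compound apart on clearance. No supporting measurement is available to explain these results.

From the compounds shown here alone, it remains open whether an amine, a carboxylic acid or a longer chain on this same carbon would also stay within the scatter. Going by these compounds, all three compounds share the rest of their structure, so it is also open whether chloro and methoxy would behave alike on a different core.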